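Anilinoquinoline series: removing one chloro from compound 2

The compounds below may be only part of what the source reports. "The series", "measured", "known", "first", "only" and "open" are said of these compounds alone.

Measured compounds:
compound 1 `CC(C)c1ccc(Nc2ccc3c(OCCCN4CCN(C)CC4)cccc3n2)cc1` — 15600 nM
compound 2 `CN1CCN(CCCOc2cccc3nc(Nc4cc(Cl)cc(Cl)c4)ccc23)CC1` — 1980 nM

In a functional assay on A549 cells (Homo sapiens) for inhibition, read by sulforhodamine B assay, with a stated time of 48 h (on this read-out higher numbers stand for weaker inhibition of growth and lower numbers for stronger inhibition of growth), compound 1 gives 15600 nM. In this assay, for the measured compounds named here, compound 2 gives 1980 nM, the lowest of the two numbers; the one step known, a 7.9-fold lower number from compound 1 to compound 2 (0.90 log units; beyond the scatter), is beyond the scatter, so the aryl group on the amine nitrogen clearly matters within this pair.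

Compound 3 `CN1CCN(CCCOc2cccc3nc(Nc4cccc(Cl)c4)ccc23)CC1` has not yet been measured. It differs from compound 2 by hydrogen in place of chloro on an aromatic carbon; the change sits on an aromatic carbon of a six-membered aromatic ring of carbon only, meta to a chloro group and meta to a large group.

Going by the values given here, no measured step removes a single chloro from this ring, so the only bearing is indirect: the step from compound 1 to compound 2 shows that what stands on this ring shifts the number by a modest amount. Compound 3 keeps one chloro of compound 2, so a step weaker than that is expected, most likely toward a higher number. Compound 3 is therefore expected at 4000 nM (range 1500 nM to 12000 nM), meaning an estimated step of a 2.0-fold higher number from compound 2 to compound 3 (0.31 log units; beyond the scatter).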

Compound 3, concentration for 50% growth inhibition: 2020 nM
Estimate against measurement, compound 3: 2.0-fold (0.30 log units) above, and the stated range covers the measured number.
By their numbers in this assay, from the lowest: compounds 2 and 3 (each within the scatter of the next); then compound 1.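

In this assay the step of a 1.0-fold higher number from compound 2 to compound 3 (0.01 log units; within the scatter) shows that, at this position on the ring, chloro and hydrogen are not separated when the other chloro stays in place, which the earlier pair could not show. The step of a 7.7-fold lower number from compound 1 to compound 3 (0.89 log units; beyond the scatter) is of the same order as the step of a 7.9-fold lower number from compound 1 to compound 2 (0.90 log units; beyond the scatter) and lies beyond the scatter, so the gap to the 4-isopropylphenyl compound remains with the 3-chlorophenyl group as it does with the 3,5-dichlorophenyl group. Nothing at hand explains why the second chloro makes no measurable difference here.

The compounds shown leave open whether the remaining chloro matters at all, since a plain phenyl group on the amine nitrogen would be needed to settle that. They also leave open whether a fluoro, methoxy or trifluoromethyl group in place of that chloro would hold the number or shift it beyond the scatter, and whether the flat response to the second chloro would persist with such groups.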